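Replacing a Fluorophenyl Ring with a Saturated Cyclohexyl Ring

The source may report more compounds than this note shows. Statements on the series, on what has been measured and on what is new or still open speak of the compounds shown alone.

Among the measured compounds shown here, compound 2 `Fc1cccc(-c2nnc3sc(/C=C/c4ccco4)nn23)c1` stands lowest of the two numbers so far measured in an assay for inhibition of histone-lysine N-methyltransferase, H3 lysine-79 specific (Homo sapiens), read by scintillation counting, with stated times of 15 min and 60 min, tested at 50 uM, in the presence of a further agent that is not named here; on this read-out higher numbers stand for a stronger effect at the one concentration tested and lower numbers for a weaker effect. In this assay compound 2 gives 22%, while compound 1 `C(=C/c1nn2c(-c3ccncc3)nnc2s1)\c1ccco1` gives 67%. For the measured compounds named here, the single step measured between them, a number 45 percentage points lower from compound 1 to compound 2 (beyond the scatter), exchanges one aromatic ring for another at the same aromatic carbon. Compound 3 `C(=C/c1nn2c(C3CCCCC3)nnc2s1)\c1ccco1` differs from compound 2 in one place: cyclohexyl in place of 3-fluorophenyl on an aromatic carbon. Going by the values given here, no measured step exchanges an aromatic ring for a non-aromatic one, so the step from compound 1 to compound 2 shows only that a change at this position can move the read-out a long way, without telling in which direction a saturated ring would move it. The expected step is therefore small, a number 2 percentage points lower from compound 2 to compound 3 (within the scatter). Compound 3 is estimated at 20%, within a range from 0% to 50%.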

Compound 3, a percentage reported as inhibition, at one concentration (the size of the read-out at that concentration, not a potency): 68%
Compound 3: middle estimate off by 48 percentage points, on the low side, and the stated range ends below it.
By their numbers in this assay, from the lowest: compound 2; then compounds 1 and 3 (each within the scatter of the next).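

In this assay, among the compounds shown here, the first measured exchange of an aromatic ring for a non-aromatic one at this position is a number 46 percentage points higher from compound 2 to compound 3 (beyond the scatter), so an aromatic ring is not required here for a high read-out. The other new step, a number 1 percentage points higher from compound 1 to compound 3 (within the scatter), places cyclohexyl level with pyridin-4-yl, so aromatic and non-aromatic rings can give matching numbers, and among these three groups only 3-fluorophenyl stands apart, with the lower number. Nothing available explains this difference between the groups.

The compounds shown leave open whether the lower number of compound 2 goes with the fluorine or with the phenyl ring itself, which a plain phenyl group would help to separate. They also leave open whether a ring is needed at all at this position, a question that an open-chain group such as n-butyl could address.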